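The source may hold more compounds than are shown below. What is called first, only, known or untested is meant among the compounds shown, and "the series" means these compounds.

Measured in a functional assay on HOP-62 cells (Homo sapiens) for inhibition, read by sulforhodamine B assay; a higher number here means a weaker inhibitor of growth, a lower number a stronger inhibitor of growth:
compound 1 `FC(F)(F)c1ccc(-c2ccc(-c3ccc(-c4nc5ccccc5[nH]4)cc3)cc2)cc1` gives 100000 nM
compound 2 `COc1ccc(-c2ccc(-c3ccc(-c4nc5ccccc5[nH]4)cc3)cc2)cc1` gives 100000 nM
compound 3 `COc1ccc(-c2ccc(-c3ccc(-c4nc5ccccc5[nH]4)cc3)cc2)cc1OC` gives 4200 nM

Compound 1 stands level with compound 2, and together they hold the highest of the three numbers. Compound 4 (`Cc1ccc2[nH]c(-c3ccc(-c4ccc(-c5ccc(C(F)(F)F)cc5)cc4)cc3)nc2c1`) has methyl in place of hydrogen on an aromatic carbon. The measured steps all lie elsewhere in the molecule. One stayed within the scatter (no change at the digits printed from compound 1 to compound 2 (within the scatter)), while two were large (a 24-fold lower number from compound 2 to compound 3 (1.38 log units; beyond the scatter); a 24-fold lower number from compound 1 to compound 3 (1.38 log units; beyond the scatter)). None measures a change at the site of the new methyl, so no step beyond the scatter is expected in this assay. The expected step is small (a 1.7-fold lower number from compound 1 to compound 4 (0.22 log units; within the scatter)). The estimate for compound 4 is 60000 nM (expected range 10000 nM to 120000 nM).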

Compound 4, concentration for 50% growth inhibition: 24200 nM
The estimate for compound 4 lay 2.5-fold (0.39 log units) above the measured number; the measured number falls inside the stated range.
By their numbers in this assay, from the lowest: compound 3; then compound 4; then compounds 1 and 2 (each within the scatter of the next).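

In this assay, the change from 1H-benzimidazol-2-yl to 5-methyl-1H-benzimidazol-2-yl gives a 4.1-fold lower number from compound 1 to compound 4 (0.62 log units; beyond the scatter) and so lies beyond the scatter. Within the data shown here, this shows that the number also responds at this end of the molecule, which none of the earlier steps touched, and that a single methyl is enough to shift it. Nothing available bears on the cause of this step. Going by these compounds, it remains open whether methyl would have a similar effect in the 3,4-dimethoxyphenyl compound 3. On these data alone, whether an amine, a carboxylic acid or a longer chain on this aromatic carbon would lower the number further also remains open.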